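The compounds below may be only part of what the source reports. "The series", "measured", "known", "first", "only" and "open" are said of these compounds alone.

Compound 1 `COC1=C(C)C(=O)/C(=C(O)/C=C/c2ccc(Br)cc2)C(=O)C1(C)C`: < 4 ug/mL
Compound 2 `COC1=C(C)C(=O)/C(=C(O)/C=C/c2ccc(O)cc2)C(=O)C1(C)C`: < 4 ug/mL
Compound 3 `COC1=C(C)C(=O)/C(=C(O)/C=C/c2ccc(C)cc2)C(=O)C1(C)C`: < 4 ug/mL

Each entry is a limit of a functional assay on HUVEC cells (Homo sapiens) (a higher number here means that more compound is needed for the effect, a lower number that less compound is needed), not a number. Compound 3 stands at < 4 ug/mL, which is likewise only a limit. All three share this position: the limit of < 4 ug/mL in this assay, at which 3 of the 3 values shown sit.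

Compound 4 `COC1=C(C)C(=O)/C(=C(O)/C=C/c2ccccc2C)C(=O)C1(C)C` has the same atoms as compound 3, joined differently: 2-methylphenyl in place of 4-methylphenyl on a double-bonded chain carbon bound to a double-bonded chain carbon.

The measured changes are a step that the two limits leave unreadable from compound 1 to compound 3, a step that the two limits leave unreadable from compound 2 to compound 3 and a step that the two limits leave unreadable from compound 1 to compound 2. None can be sized, and none swaps 4-methylphenyl for 2-methylphenyl. Among the measured compounds shown here, the only guide is therefore the limit of compound 3, < 4 ug/mL. The expected change is a step that the limit leaves unreadable from compound 3 to compound 4, with no direction and nothing beyond the scatter foreseen. Compound 4 is estimated at 2.5 ug/mL, with an expected range from 0.8 ug/mL to 6 ug/mL.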

Compound 4, concentration for half-maximal effect: < 4 ug/mL
Compound 4: no number, only a limit; the forecaster's own chance of this, stated with the estimate: 75%; the middle value lies beyond the limit too.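

In this assay compound 4 gives only a limit, as do compound 1, compound 2 and compound 3, so none of the steps to compound 4 can be read. Going by these compounds, how far each compound lies beyond that limit, and whether 2-methylphenyl and 4-methylphenyl differ at all, remains open.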